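The source may hold more compounds than are shown below. What is called first, only, known or untested is meant among the compounds shown, and "the series" means these compounds.

Working notes on the series. Two compounds carry numbers in a functional assay on HEK293 cells for agonist activity at D(4) dopamine receptor (Homo sapiens), read by FLIPR; on this read-out lower numbers stand for smaller maximal responses and higher numbers for larger maximal responses. Compound 1 `Cc1cccc(NC(=O)CN2CCC(c3nccs3)CC2)c1` gives 62% in this assay. Compound 2 `O=C(CN1CCC(c2cccc[n+]2[O-])CC1)Nc1ccc(F)cc1F` gives 74% in this assay, the higher of the two numbers, and the gap to compound 1 lies beyond the usual scatter. Within the data shown here, compound 1 and compound 2 differ in more than one place, so the gap cannot be tied to one change; it shows only that compound 2 reaches the larger maximal response of the pair.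

Compound 3 `Cc1ccc(Cl)cc1NC(=O)CN1CCC(c2cccc[n+]2[O-])CC1` has not yet been measured. It differs from compound 2 as follows: 5-chloro-2-methylphenyl in place of 2,4-difluorophenyl on an amide-type nitrogen. Among the measured compounds shown here, no step between measured compounds that differ in a single place is available here, so there is no direct guide for the size of this change. The expectation is a step of about the usual scatter or less, with no clear direction. Compound 3 is expected to give about 68% in this assay, within 50% to 86%. The expected step from compound 2 to compound 3 is thus a number 6 percentage points lower from compound 2 to compound 3 (within the scatter).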

Compound 3, largest response reached (reported as efficacy), in percent of the reference or control that the assay uses: 58%
Compound 3: middle estimate off by 10 percentage points, on the high side; low and high end bracket the measured number.
By their numbers in this assay, from the lowest: compounds 3 and 1 (each within the scatter of the next); then compound 2.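

In this assay, among these compounds, 5-chloro-2-methylphenyl in place of 2,4-difluorophenyl on an amide-type nitrogen gives a number 16 percentage points lower from compound 2 to compound 3 (beyond the scatter) and is the first change that can be tied to one place. The maximal response is thus sensitive to the aryl group on this nitrogen, even though the two groups match in heavy-atom count and neither carries a hydrogen-bond donor or acceptor. No available measurement accounts for this step, so its origin stays unassigned.

Among the compounds shown here, with only two aryl groups compared here, the separate contributions of the chlorine, the methyl and the two fluorines remain unresolved. Also open, going by these compounds, is how an unsubstituted phenyl or a 4-methoxyphenyl would behave on this nitrogen, and whether the same exchange gives a similar step on the core of compound 1.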